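Amide aryl swaps in one antiproliferative series

The compounds below may be only part of what the source reports. "The series", "measured", "known", "first", "only" and "open" are said of these compounds alone.

For the measured compounds named here, compound 1 `O=C(Nc1cccc(-c2oc3cc(-c4ccc(F)cc4)ccc3c(=O)c2O)c1)c1ccc(Cl)cc1` gives 10800 nM in a functional assay on A549 cells (Homo sapiens) for antiproliferative activity, read by CCK-8 assay, with a stated time of 72 h (on this read-out higher numbers stand for weaker inhibition and lower numbers for stronger inhibition), and stands second highest of the three numbers so far. Compound 2 `COc1ccc(C(=O)Nc2cccc(-c3oc4cc(-c5ccc(F)cc5)ccc4c(=O)c3O)c2)c(F)c1` gives 40000 nM in this assay, and compound 3 `Cc1cc(C)cc(C(=O)Nc2cccc(-c3oc4cc(-c5ccc(F)cc5)ccc4c(=O)c3O)c2)c1` gives 3740 nM. The two measured changes at the carbonyl carbon run opposite ways: a 3.7-fold higher number from compound 1 to compound 2 (0.57 log units; beyond the scatter), whereas a 2.9-fold lower number from compound 1 to compound 3 (0.46 log units; beyond the scatter). Compound 4 `O=C(Nc1cccc(-c2oc3cc(-c4ccc(F)cc4)ccc3c(=O)c2O)c1)c1cnc(Cl)nc1Cl` is not yet measured; it differs from compound 1 as follows: 2,4-dichloropyrimidin-5-yl in place of 4-chlorophenyl on a carbonyl carbon. Both earlier steps at this position were modest, and no earlier case of a ring with hetero atoms entering here exists, so only a modest step in either direction from compound 1 can be read in. Compound 4 is therefore expected to give about 12000 nM, within 4000 nM to 40000 nM. The expected step is a 1.1-fold higher number from compound 1 to compound 4 (0.05 log units; within the scatter).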

Compound 4, half-maximal inhibitory concentration: > 100000 nM
Compound 4 ended at the assay's limit (the forecaster's own chance of this, stated with the estimate: 10%); middle value at least 8.3-fold (0.92 log units) away from the limit.
By their numbers in this assay, from the lowest: compound 3; then compound 1; then compound 2. At a limit, above all of these: compound 4.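

In this assay compound 4 gives > 100000 nM, a limit of the assay and not a number: the limit of > 100000 nM in this assay, at which 1 of the 4 values shown sits. This position is therefore not open to every aryl group, and 2,4-dichloropyrimidin-5-yl, the only ring here with hetero atoms, sits above all three carbon-only rings: an at least 9.2-fold higher number from compound 1 to compound 4 (0.96 log units; beyond the scatter), an at least 26-fold higher number from compound 3 to compound 4 (1.42 log units; beyond the scatter) and an at least 2.5-fold higher number from compound 2 to compound 4 (0.39 log units; beyond the scatter). The ring nitrogens and the added chlorine change together in this swap, so the compounds shown cannot separate them. Going by these compounds, a pyrimidine ring without chlorine and a dichlorophenyl group on the same carbonyl carbon remain open.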